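Imide nitrogen substitution: naphthalen-1-yl replacing 4-chlorophenyl

A few compounds are considered here, and "the series" means these few. Any claim that something is new, unique, unknown or untested is made for them only; others in the source may bear on it.

Measured compounds:
- In a functional assay on KB cells (Homo sapiens) for antiproliferative activity, read by MTT assay, with a stated time of 48 h (a higher number here means a weaker inhibitor, a lower number a stronger inhibitor), compound 1 `Cn1cc(C2=C(c3nn(CCn4ccnc4)c4ncccc34)C(=O)NC2=O)c2ccccc21` gives > 100000 nM, which is a limit of the assay.
- In this assay compound 2 `Cn1cc(C2=C(c3nn(CCCN4CCCCC4)c4ncccc34)C(=O)N(c3ccc(Cl)cc3)C2=O)c2ccccc21` gives > 100000 nM, which is a limit of the assay.
- In this assay compound 3 `Cn1cc(C2=C(c3nn(CCCn4cccc4)c4ncccc34)C(=O)NC2=O)c2ccccc21` gives > 100000 nM, which is a limit of the assay.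

Compound 2 stands at the limit, as do the other two values shown: the limit of > 100000 nM in this assay, at which 3 of the 3 values shown sit. No numbered value exists anywhere in the set.

Among the measured compounds shown here, the one single-point change between measured compounds, a step that the two limits leave unreadable from compound 1 to compound 3, cannot be read as a size because both ends are limits.

Compound 4 `Cn1cc(C2=C(c3nn(CCCN4CCCCC4)c4ncccc34)C(=O)N(c3cccc4ccccc34)C2=O)c2ccccc21` differs from compound 2 at the amide-type nitrogen in the ring: naphthalen-1-yl in place of 4-chlorophenyl on an amide-type nitrogen in a ring

For the measured compounds named here, no measured step touches this nitrogen substituent, and the only measured pair that does carry a substituent there, compound 2, sits at the limit. Nothing in the set therefore gives a direction or size for this change in this assay. With all three values at the limit, the expected outcome for compound 4 is a further limit or a value close to it.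

Compound 4 is estimated at 100000 nM in this assay, within 20000 nM to 300000 nM. The estimated step of a number no higher from compound 2 to compound 4 (the limit leaves the size open) is thus expected to be essentially none beyond the scatter.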

Compound 4, half-maximal inhibitory concentration: 13400 nM
For compound 4 the middle estimate is 7.5-fold (0.87 log units) above the measured one; the measured number lies below the stated range.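

In this assay, among the compounds shown here, compound 4 gives 13400 nM, the only numbered value shown, which makes the substituent on the amide-type nitrogen in a ring the one place in the set where a change can be read. Naphthalen-1-yl in place of 4-chlorophenyl gives an at least 7.4-fold lower number from compound 2 to compound 4 (0.87 log units; beyond the scatter), so the side chain shared by compound 2 and compound 4 does not by itself hold the series at the limit. Only one end of this step is a number, and its size therefore stays a lower bound: the limit of > 100000 nM in this assay, at which 3 of the 4 values shown sit.

This single pair does not separate what naphthalen-1-yl brings from what leaving 4-chlorophenyl removes, and a plain phenyl, a naphthalen-2-yl or a benzyl group on the same nitrogen would be needed to tell these apart. Also open, from the compounds shown here alone, is whether the step carries over to a side chain ending in a morpholine or a dimethylamine, while the step between the two compounds with the amide hydrogen, both at the limit, cannot be read.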